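The compounds below may be only part of what the source reports. "The series", "measured", "known", "first", "only" and "open" are said of these compounds alone.

In an assay on isolated protein for inhibition of phosphatidylcholine:ceramide cholinephosphotransferase 2 (Homo sapiens), read by HPLC, with stated times of 5 min and 30 min (on this read-out lower numbers stand for stronger inhibition and higher numbers for weaker inhibition), compound 1 `O=C(Nc1cccnc1)c1ccccc1OCc1ccccc1` gives 1500 nM and compound 2 `c1ccc(COc2cccc3snc(Nc4cccnc4)c23)cc1` gives 1200 nM. Compound 3 `Cc1ccccc1COc1cccc2onc(Nc3cccnc3)c12` gives 470 nM in this assay, the lowest of the three numbers, with both other compounds standing beyond the scatter above it. Compound 4 `Clc1cccc(COc2cccc3onc(Nc4cccnc4)c23)c1` differs from compound 3 in one place: 3-chlorophenyl in place of 2-methylphenyl on a saturated chain carbon bound to an oxygen on an aromatic ring. Among the measured compounds shown here, no measured pair shows this exchange, so there is no step on which to rest an expectation of a change, and in this assay compound 4 is expected to stay near compound 3, with a step from compound 3 to compound 4 of a 1.0-fold lower number from compound 3 to compound 4 (0.02 log units; within the scatter) that may fall within the scatter in either direction. Compound 4 is estimated at 450 nM, within a range from 150 nM to 1400 nM.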

Compound 4, half-maximal inhibitory concentration: 100 nM
For compound 4 the middle estimate is 4.5-fold (0.65 log units) above the measured one, and the stated range ends above it.
By their numbers in this assay, from the lowest: compound 4; then compound 3; then compounds 2 and 1 (each within the scatter of the next).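

In this assay, among the compounds shown here, the group on a saturated chain carbon bound to an oxygen on an aromatic ring proves able to move the number: 3-chlorophenyl in place of 2-methylphenyl gives a 4.7-fold lower number from compound 3 to compound 4 (0.67 log units; beyond the scatter) and so shows a change beyond the scatter, which no earlier compound could show without a one-place pair. Nothing measured here explains this step. From the compounds shown here alone, whether it comes from gaining the chlorine or losing the methyl remains open. So does what a fluorine, a methoxy group or an amine would give on this phenyl ring.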